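The source may report more compounds than this note shows. Statements on the series, on what has been measured and on what is new or still open speak of the compounds shown alone.

Compound 1 `COc1ccc(/C=C/C(=O)c2ccccc2-c2cccc(F)c2)cc1` and compound 2 `COc1ccc(/C=C/C(=O)c2ccccc2-c2cccc(F)c2)cc1OC` share one core, and both were tested in a functional assay on A549 cells (Homo sapiens) for antiproliferative activity, read by sulforhodamine B assay, with a stated time of 48 h; a higher number here means a weaker inhibitor, a lower number a stronger inhibitor. In this assay compound 1 gives 280 nM. In this assay compound 2 gives 330 nM. The change between them is methoxy in place of hydrogen on an aromatic carbon, and it made a 1.2-fold higher number from compound 1 to compound 2 (0.07 log units; within the scatter). Compound 3 `COc1ccc(CNC(=O)c2ccccc2-c2ccc(F)cc2)cc1` is built on a different core; how the two cores differ is not broken down here. In this assay compound 3 reached only the limit of the assay, > 50000 nM, which is not a number but the edge of what the test can report (the limit of > 50000 nM in this assay, at which 1 of the 3 values shown sits). Compound 4 `COc1ccc(CNC(=O)c2ccccc2-c2ccc(F)cc2)cc1OC` carries the same change on the core of compound 3, namely (methoxy in place of hydrogen on an aromatic carbon), with the same surroundings as in the pair of compound 1 and compound 2. Since that change made only a 1.2-fold higher number from compound 1 to compound 2 (0.07 log units; within the scatter), it is expected to leave the weak activity of compound 3 essentially where it is, so compound 4 is expected to stay at or near the limit, around 50000 nM, an expected step of a number no higher from compound 3 to compound 4 (the limit leaves the size open), with the range 20000 nM to 200000 nM.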

Compound 4, half-maximal inhibitory concentration: > 50000 nM
Compound 4 was reported as a limit; the forecaster's own chance of this, stated with the estimate: 85%; the middle value lies on the limit itself.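

Going by these compounds alone, compound 3 and compound 4 each reached only a limit in this assay, not a number, so no step between them can be read: the limit of > 50000 nM in this assay, at which 2 of the 4 values shown sit.

The compounds shown leave open how weak compound 3 and compound 4 really are, and whether methoxy in place of hydrogen changes activity at all on this core.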